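Swapping dimethylamino for methoxy in a growth inhibitor

This account rests on a few compounds, and the source may have more. Where it says the series, first, only, none or still open, it means among the compounds named here.

Of the compounds shown here, two have been measured so far in a functional assay on MDA-N cells (Homo sapiens) for inhibition; on this read-out lower numbers stand for stronger inhibition of growth and higher numbers for weaker inhibition of growth. Compound 1 (`CN(C)c1ccc(NS(=O)(=O)c2c(F)c(F)c(F)c(F)c2F)cc1`) gives 30 nM, the lower of the two numbers. Compound 2 (`Cc1ccc(NS(=O)(=O)c2c(F)c(F)c(F)c(F)c2F)cc1C`) gives 123 nM, a number higher than that of compound 1 by more than the usual scatter of repeated measurements.

Compound 3 (`COc1ccc(NS(=O)(=O)c2c(F)c(F)c(F)c(F)c2F)cc1`) has not yet been measured. It keeps the core of compound 1 and changes a single group: methoxy in place of dimethylamino on an aromatic carbon. The methoxy takes the place of dimethylamino on an aromatic carbon, para to a large group. For the measured compounds named here, no measured pair shows this change on its own, so its size can only be judged loosely. Compound 1 sits at the low end of the numbers at 30 nM, and a modest move towards a higher number, meaning weaker inhibition of growth, is therefore expected. A result within the scatter would not be surprising. In numbers, the expected step is a 2.0-fold higher number from compound 1 to compound 3 (0.30 log units; within the scatter). For compound 3 the estimated value is 60 nM, with an expected range of 25 nM to 150 nM.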

Compound 3, concentration for 50% growth inhibition: 41 nM
Compound 3: the middle estimate sits 1.5-fold (0.17 log units) above what was measured, and the stated range covers the measured number.
By their numbers in this assay, from the lowest: compounds 1 and 3 (each within the scatter of the next); then compound 2.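

In this assay, for the compounds shown here, the swap of dimethylamino for methoxy gives a 1.4-fold higher number from compound 1 to compound 3 (0.14 log units; within the scatter) and is the first single-place comparison, so compound 1 and compound 3 cannot be told apart on this read-out. At this aromatic carbon, para to a large group, the nitrogen-linked dimethylamino with its 3 heavy atoms can therefore give way to the oxygen-linked methoxy with its 2 heavy atoms without a difference that stands out from the usual scatter, so dimethylamino is not shown to be needed here for a low number. Nothing available explains why these two groups give such similar numbers.

The compounds shown leave open how far this tolerance extends, since only two groups have been compared at this position, and a free amine, a hydroxyl, an ethoxy or longer alkoxy chain, or a carboxylic acid might or might not fall within the scatter of compound 1. They also leave open whether the same swap would give a similar step on a different core or in another cell line.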